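Chloro for hydroxy on the pendant phenyl ring

This account rests on a few compounds, and the source may have more. Where it says the series, first, only, none or still open, it means among the compounds named here.

Measured compounds:
- compound 1 `C=CCc1c(O)cc(O)c2c1OC(c1cccc(Cl)c1)CC2=O` gives 76.7%
- compound 2 `C=CCc1c(O)cc(O)c2c1OC(c1cccc(O)c1)CC2=O` gives 97.8%
- compound 3 `C=CCc1c(O)ccc2c1OC(c1ccc(O)cc1)CC2=O` gives 87.2%

The three values above come from a functional assay on aorta (Rattus norvegicus, strain Sprague-Dawley) for inhibition, with a stated time of 20 min; on this read-out lower numbers stand for smaller maximal responses and higher numbers for larger maximal responses. Compound 2 and compound 1 share a core and differ in one place, where (chloro in place of hydroxy on an aromatic carbon). This change carried the step of a number 21.1 percentage points lower from compound 2 to compound 1 (beyond the scatter). Compound 4 `C=CCc1c(O)ccc2c1OC(c1ccc(Cl)cc1)CC2=O` has not yet been measured in this assay. It stands to compound 3 as compound 1 stands to compound 2: chloro in place of hydroxy on an aromatic carbon. The two changes are the same kind of change but not the same one, since in compound 1 the chloro sits meta to a large group while in compound 4 it sits para to a large group. How the core of compound 3 differs from the core of compound 2 is not broken down here; the values of the two compounds are what they are.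

Going by the values given here, the step from compound 3 to compound 4 is expected to run the same way as the earlier one, because a number 21.1 percentage points lower from compound 2 to compound 1 (beyond the scatter) is the only measured example of this kind of change. The step is estimated at a number 19.2 percentage points lower from compound 3 to compound 4 (beyond the scatter). Compound 4 is therefore expected to reach about 68% in this assay, with a range from 55% to 82%.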

Compound 4, largest response reached (Emax), in percent of the reference or control that the assay uses: 70.8%
Estimate against measurement, compound 4: 2.8 percentage points below; low and high end bracket the measured number.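

In this assay, the chloro-for-hydroxy change on the second core again gave a smaller maximal response, with a number 16.4 percentage points lower from compound 3 to compound 4 (beyond the scatter). Set beside the earlier step, the change carried from one core to the other in both direction and size: the same change on two cores in this assay, a number 21.1 percentage points lower (beyond the scatter) from compound 2 to compound 1 and a number 16.4 percentage points lower (beyond the scatter) from compound 3 to compound 4, 4.7 percentage points apart, within the scatter of two such steps. Going by these compounds alone, this agreement rests on only two pairs, however, and the chloro does not sit at the same place on the phenyl ring in both, so it does not show how the step would behave on other cores or separate any influence of the core from that of position.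

The compounds shown leave open whether a different group at the same place, such as an amine, a methoxy or a carboxylic acid, would lower the response as chloro does. They also leave open whether the step would hold if the allyl chain on the core were replaced by a longer chain.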